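Ether side chain: oxygen ring replaced by nitrogen ring

The source may report more compounds than this note shows. Statements on the series, on what has been measured and on what is new or still open speak of the compounds shown alone.

Compound 2 `CC1(C)CCC(CN2CCN(c3ccc(C(=O)NS(=O)(=O)c4ccc(OCC5CCCOC5)c([N+](=O)[O-])c4)c(Oc4cnc5[nH]ccc5c4)c3)CC2)=C(c2ccc(C(F)(F)F)cc2)C1` gives 3 nM in an assay on isolated protein for displacement of a labelled ligand from Apoptosis regulator Bcl-2 (Homo sapiens), with a stated time of 15 min; a higher number here means a weaker inhibitor, a lower number a stronger inhibitor. Compound 1 `CC1(C)CCC(CN2CCN(c3ccc(C(=O)NS(=O)(=O)c4ccc(OCC5CCOC5)c([N+](=O)[O-])c4)c(Oc4cnc5[nH]ccc5c4)c3)CC2)=C(c2ccc(C(F)(F)F)cc2)C1` gives 4.4 nM in this assay, and the step of a 1.5-fold lower number from compound 1 to compound 2 (0.17 log units; within the scatter) lies within the scatter, so compounds 1 and 2 stand level on the numbers shown. Compound 3 `CCN1CCC(COc2ccc(S(=O)(=O)NC(=O)c3ccc(N4CCN(CC5=C(c6ccc(C(F)(F)F)cc6)CC(C)(C)CC5)CC4)cc3Oc3cnc4[nH]ccc4c3)cc2[N+](=O)[O-])CC1` differs from compound 2 by 1-ethylpiperidin-4-yl in place of oxan-3-yl on a saturated chain carbon bound to an oxygen on an aromatic ring. Among the compounds with values here, the only measured step at this place, a 1.5-fold lower number from compound 1 to compound 2 (0.17 log units; within the scatter), was small and swapped one saturated oxygen ring for another; here the ring hetero atom becomes nitrogen and the ring carries an ethyl group, a change not yet sampled. No step beyond the scatter is expected, with the range widened for the unsampled change. Compound 3 is estimated at 3.5 nM, between 1 nM and 12 nM, meaning an expected step of a 1.2-fold higher number from compound 2 to compound 3 (0.07 log units; within the scatter).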

Compound 3, half-maximal inhibitory concentration: 0.5 nM
Compound 3: middle estimate off by 7.0-fold (0.85 log units), on the high side; measured number outside the range, below it.
By their numbers in this assay, from the lowest: compound 3; then compounds 2 and 1 (each within the scatter of the next).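

This position is not flat: in this assay, 1-ethylpiperidin-4-yl in place of oxan-3-yl gives a 6.0-fold lower number from compound 2 to compound 3 (0.78 log units; beyond the scatter), and in place of oxolan-3-yl it gives an 8.8-fold lower number from compound 1 to compound 3 (0.94 log units; beyond the scatter). Both steps lie beyond the scatter, whereas the swap between the two saturated oxygen rings stayed within it. No supporting measurement bears on this result.

From the compounds shown here alone, the change alters the ring hetero atom, the ring attachment point and the ethyl group together, so their separate contributions remain open. Piperidin-4-yl without the ethyl group, or 1-methylpiperidin-4-yl, would help separate them.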